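The compounds below may be only part of what the source reports. "The series", "measured", "known", "first", "only" and "open" are said of these compounds alone.

In a functional assay on the whole organism with Rattus norvegicus as the target (a higher number here means that more compound is needed for the effect, a lower number that less compound is needed), compound 1 `N=c1sc2cc(OC(F)(F)F)ccc2n1Cc1ccccc1` reads > 10 mg/kg, which is a limit of the assay and not a number. Among the measured compounds shown here, compound 2 `N=c1sc2cc(OC(F)(F)F)ccc2n1CCSc1ccccc1` gives 4.5 mg/kg, the only true number so far, so it has no measured neighbour to be ranked against. Compound 3 `CS(=O)(=O)CCCn1c(=N)sc2cc(OC(F)(F)F)ccc21` keeps the shared core and carries (methylsulfonyl)methyl in place of phenylsulfanyl on a saturated chain carbon, two bonds along the chain from an aromatic nitrogen.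

For the measured compounds named here, one measured step bears on this change: an at least 2.2-fold lower number from compound 1 to compound 2 (0.34 log units; beyond the scatter). That step has one end at compound 1, so it rests on (the limit of > 10 mg/kg in this assay, at which 1 of the 2 values shown sits). It shows that the side chain on the aromatic nitrogen can move this assay beyond the scatter, but it does not test loss of the phenylsulfanyl group or arrival of a sulfonyl group. No step beyond the scatter is therefore expected as the most likely outcome, with a slight lean towards a higher number and a wide margin on both sides. The expected change is a 1.3-fold higher number from compound 2 to compound 3 (0.12 log units; within the scatter). For compound 3 the estimate is 6 mg/kg, with an expected range of 2 mg/kg to 20 mg/kg.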

Compound 3, dose for half-maximal effect: 5 mg/kg
Compound 3: the middle estimate sits 1.2-fold (0.08 log units) above what was measured; low and high end bracket the measured number.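

In this assay, the change on a saturated chain carbon, two bonds along the chain from an aromatic nitrogen, gives a 1.1-fold higher number from compound 2 to compound 3 (0.05 log units; within the scatter), so this read-out does not separate phenylsulfanyl from (methylsulfonyl)methyl. The leaving group carries one six-membered aromatic ring of carbon only and the entering group has no ring, so for this pair an aromatic ring at the end of the chain is not needed to keep the number of compound 2. The comparison with compound 1 gives an at least 2.0-fold lower number from compound 1 to compound 3 (0.30 log units; that floor lies within the scatter), and it can be read only as a floor, since one of its ends is a limit and not a number: the limit of > 10 mg/kg in this assay, at which 1 of the 3 values shown sits.

As far as these compounds go, both groups compared at this place contain one sulfur, so it remains open whether a simple alkyl chain or an ether oxygen in place of that sulfur would hold the number of compound 2 or compound 3. From the compounds shown here alone, it is equally open how an amine, a carboxylic acid or a longer chain at this place would read, and whether the tolerance seen with these two groups extends to such groups at all.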